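The source may hold more compounds than are shown below. What is called first, only, known or untested is meant among the compounds shown, and "the series" means these compounds.

In an ADME assay on PBMC cells (Homo sapiens) for cytotoxicity, with a stated time of 5 days (on this read-out higher numbers stand for weaker inhibition and lower numbers for stronger inhibition), compound 1 `O=C(/C=C/c1ccc(N2CCCCC2)cc1)c1ccsc1` reaches only the limit of > 100000 nM. Compound 2 `Cc1ccc(C(=O)/C=C/c2ccc(N3CCCCC3)cc2)s1` gives 77800 nM. The step of an at least 1.2-fold lower number from compound 1 to compound 2 (0.10 log units; that floor lies within the scatter) is a floor because compound 1 sits at the limit of > 100000 nM in this assay, at which 1 of the 3 values shown sits. Compound 3 `c1csc(C2=NNC(c3ccc(N4CCCCC4)cc3)C2)c1` gives 20800 nM, the lowest of the two numbers, with compound 2 as its nearest neighbour at a gap beyond the usual scatter. Compound 4 `Cc1ccc(C2=NNC(c3ccc(N4CCCCC4)cc3)C2)s1` is compound 3 with methyl in place of hydrogen on an aromatic carbon. Going by the values given here, the only measured step of the same kind is an at least 1.2-fold lower number from compound 1 to compound 2 (0.10 log units; that floor lies within the scatter), whose floor lies within the scatter, so no change beyond the scatter is expected in this assay, and compound 4 is estimated at 16000 nM, between 5000 nM and 50000 nM, a step of a 1.3-fold lower number from compound 3 to compound 4 (0.11 log units; within the scatter).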

Compound 4, half-maximal inhibitory concentration: 86400 nM
Compound 4: middle estimate off by 5.4-fold (0.73 log units), on the low side; measured number above the stated range.
By their numbers in this assay, from the lowest: compound 3; then compounds 2 and 4 (each within the scatter of the next). At a limit, above all of these: compound 1.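

Here methyl in place of hydrogen, next to the ring sulfur, is the only change, and in this assay it gives a 4.2-fold higher number from compound 3 to compound 4 (0.62 log units; beyond the scatter). On this core, then, the methyl goes with weaker inhibition, by a step beyond the scatter. The earlier step changed the ring's attachment as well, and its size cannot be read because compound 1 sits at a limit: the limit of > 100000 nM in this assay, at which 1 of the 4 values shown sits.

From the compounds shown here alone, whether an ethyl group or a chlorine atom at this position would act like methyl stays open. So does whether removing the methyl from compound 2 would shift its number the same way.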